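The source may hold more compounds than are shown below. What is called first, only, known or untested is meant among the compounds shown, and "the series" means these compounds.

The measured compounds:
Compound 1, `O=C(CCCCCCc1ccccc1)c1nc(-c2ccccn2)co1`: 10000 nM
Compound 2, `O=C(CCCCCCc1ccccc1)c1nc(-c2ccncc2)co1`: 700 nM

In an assay on isolated protein for inhibition of liver carboxylesterase 1 (Homo sapiens) (a higher number here means a weaker inhibitor, a lower number a stronger inhibitor), compound 2 stands lowest of the two numbers recorded, with 700 nM. Within the data shown here, its only neighbour is compound 1, and the step between them is large: a 14-fold lower number from compound 1 to compound 2 (1.15 log units; beyond the scatter), an exchange of one pyridinyl for another on the shared core.

Compound 3, `O=C(CCCCCCc1ccccc1)c1nc(C(F)(F)F)co1`, departs from compound 2 in one place: trifluoromethyl in place of pyridin-4-yl on an aromatic carbon. Among the measured compounds shown here, no measured step covers this change. For the measured compounds named here, the single step recorded, a 14-fold lower number from compound 1 to compound 2 (1.15 log units; beyond the scatter), shows that the aromatic group on this carbon of the core matters strongly to the read-out, but it compares two pyridinyl groups and says nothing direct about removing such a group altogether in favour of trifluoromethyl. With the acceptor-bearing pyridin-4-yl gone, the number for compound 3 is expected to rise beyond the scatter, by about a 5.0-fold higher number from compound 2 to compound 3 (0.70 log units; beyond the scatter), though with wide uncertainty. Compound 3 is therefore estimated at 3500 nM, in a range from 700 nM to 15000 nM.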

Compound 3, half-maximal inhibitory concentration: 60 nM
Estimate against measurement, compound 3: 58-fold (1.77 log units) above, and the stated range ends above it.
By their numbers in this assay, from the lowest: compound 3; then compound 2; then compound 1.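

In this assay, the two pyridinyl groups seen earlier did not mark the lowest number this position can give: trifluoromethyl, with no ring and no hydrogen-bond acceptor, gives a 12-fold lower number from compound 2 to compound 3 (1.07 log units; beyond the scatter), and against the weaker pyridine it gives a 170-fold lower number from compound 1 to compound 3 (2.22 log units; beyond the scatter). Among these compounds, the earlier step showed only that one pyridinyl group differs sharply from another on this aromatic carbon next to the ring nitrogen, whereas these steps show that neither an aromatic ring nor a ring nitrogen in the substituent is required here for a number lower than either pyridinyl compound gives. No measurement at hand explains why this exchange lowers the number.

The three compounds leave open whether the low number belongs to trifluoromethyl in particular or would also follow with another small ring-free group on this carbon, such as methyl, chlorine or a nitrile, and how an unsubstituted phenyl would compare with the pyridinyl groups. They also leave open whether the step from pyridin-4-yl to trifluoromethyl keeps its size on a shorter chain, or with an amide in place of the carbonyl.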